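Aryl swap on the saturated ring carbon: compound 1 to compound 4

The source may hold more compounds than are shown below. What is called first, only, known or untested is meant among the compounds shown, and "the series" means these compounds.

Three compounds of the series have been measured in an assay on isolated protein for inhibition of Amine oxidase [flavin-containing] B (Homo sapiens), read by fluorescence; a lower number here means a stronger inhibitor, a higher number a weaker inhibitor:

- compound 1 `CC(=O)N1N=C(c2cc(O)c(O)c([N+](=O)[O-])c2)CC1c1ccco1` gives 77400 nM
- compound 2 `N#Cc1cccc(/C=C/C(=O)c2cc(O)c(O)c([N+](=O)[O-])c2)c1` gives 60600 nM
- compound 3 `O=C(/C=C/c1cccs1)c1cc(O)c(O)c([N+](=O)[O-])c1` gives 62900 nM

All three numbers sit close together. Compound 1 has the highest number of the three, but its gap to compound 3 and its gap to compound 2 both lie within the usual scatter, so no order among them can be read from these values, and none of the three stands out in this assay.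

Compound 4 `CC(=O)N1N=C(c2cc(O)c(O)c([N+](=O)[O-])c2)CC1c1ccc(C#N)cc1` has not been measured yet. It differs from compound 1 in one place: 4-cyanophenyl in place of furan-2-yl on a saturated ring carbon. The shared core and the acetyl group are unchanged.

Among the measured compounds shown here, no step between two measured compounds that differ in one place is available, so there is no measured precedent for a change of this kind. The three values recorded so far are all weak and essentially level, and nothing in them points to a direction for this change. The expectation is therefore a step of a 1.1-fold lower number from compound 1 to compound 4 (0.04 log units; within the scatter), that is, nothing beyond the scatter. Compound 4 is estimated at 70000 nM, with a range from 25000 nM to 200000 nM, and with a real chance that this assay reports only a limit for it.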

Compound 4, half-maximal inhibitory concentration: 83200 nM
Beside the measured number, compound 4's estimate is 1.2-fold (0.08 log units) below it; the measured number falls inside the stated range.
By their numbers in this assay, from the lowest: compounds 2, 3, 1 and 4 (each within the scatter of the next).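

Placing 4-cyanophenyl instead of furan-2-yl on the saturated ring carbon gives, in this assay, a step of a 1.1-fold higher number from compound 1 to compound 4 (0.03 log units; within the scatter), so compound 1 and compound 4 cannot be told apart. Among the compounds shown here, this is the first comparison between two compounds that differ in one place, and it shows that a five-membered aromatic ring with one oxygen and a larger six-membered carbon ring bearing a nitrile read alike at this position, with the shared core and the acetyl group unchanged. No measurement at hand offers an explanation for this level reading.

Going by these compounds, both groups compared here are aromatic rings, so it remains open whether this ring carbon would respond to a group of another kind, such as a simple alkyl chain, or to a phenyl ring carrying an amine or a carboxylic acid. The acetyl group is common to compound 1 and compound 4, so the same two compounds say nothing about whether a longer acyl chain on that ring nitrogen would shift the number in this assay.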